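This account rests on a few compounds, and the source may have more. Where it says the series, first, only, none or still open, it means among the compounds named here.

Among the measured compounds shown here, in a functional assay on 786-0 cells (Homo sapiens) for inhibition (on this read-out lower numbers stand for stronger inhibition of growth and higher numbers for weaker inhibition of growth), compound 1 (`NC(=O)c1cc(Cl)ccc1NC(=O)COc1ccccc1`) gives 9540 nM and compound 2 (`NC(=O)c1cc(I)ccc1NC(=O)COc1ccccc1`) gives 1070 nM as the lower of the two numbers so far. Compound 2 therefore stands lowest on the numbers shown. Its neighbour, compound 3 (`COc1ccc(NC(=O)COc2ccccc2)c(C(N)=O)c1`), has methoxy in place of iodo on an aromatic carbon that lies meta to a carbamoyl group and para to a large group.

For the measured compounds named here, only one measured step bears on this change. That step, an 8.9-fold lower number from compound 1 to compound 2 (0.95 log units; beyond the scatter), is modest but beyond the scatter, and it is iodo in place of chloro on the same aromatic carbon. Methoxy itself has not been measured on this core, so the data offer only an indirect guide. With compound 2 at 1070 nM and iodo the better of the two groups measured here, losing iodo is expected to raise the number by somewhat less than that earlier step. The expected change is a 4.2-fold higher number from compound 2 to compound 3 (0.62 log units; beyond the scatter) as a rough estimate. In this assay the estimate for compound 3 is 4500 nM with an expected range from 1400 nM to 15000 nM at the upper end.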

Compound 3, concentration for 50% growth inhibition: 2100 nM
For compound 3 the middle estimate is 2.1-fold (0.33 log units) above the measured one; low and high end bracket the measured number.
By their numbers in this assay, from the lowest: compounds 2 and 3 (each within the scatter of the next); then compound 1.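

Iodo is not the only group on this aromatic carbon, meta to a carbamoyl group and para to a large group, that separates a compound from the chloro compound: the change to methoxy gives a 4.5-fold lower number from compound 1 to compound 3 (0.66 log units; beyond the scatter) in this assay on the shared core. Replacing iodo with methoxy gives a 2.0-fold higher number from compound 2 to compound 3 (0.29 log units; within the scatter) and so does not separate the two groups, even though they share no atom and methoxy brings a hydrogen-bond acceptor that iodo lacks, which means that on these compounds the halogen series alone no longer describes what this position tolerates. No measurement at hand accounts for chloro standing apart from both iodo and methoxy on this read-out.

The compounds shown leave open how an amine, a carboxylic acid or a longer chain such as ethoxy would compare with iodo and methoxy on this carbon, and whether a plain hydrogen there would match chloro or the other two groups. They also leave open whether the closeness of iodo and methoxy holds in other cell lines or with other groups elsewhere on the shared core.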